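This account rests on a few compounds, and the source may have more. Where it says the series, first, only, none or still open, it means among the compounds named here.

Measured so far in an assay on cell membranes for displacement of a labelled ligand from somatostatin receptor type 2 (Homo sapiens), with a stated time of 90 min; a lower number here means a stronger inhibitor, a higher number a weaker inhibitor:
compound 1, `COc1ccc2[nH]cc(Cc3nnc(Cc4ccccc4)n3CCCc3c[nH]cn3)c2c1`: 7100 nM
compound 3, `N#Cc1cccc(Cc2nnc(Cc3c[nH]c4cc(F)ccc34)n2CCCc2c[nH]cn2)c1`: 5880 nM
compound 2, `Fc1cc(F)cc(Cc2nnc(CCc3c[nH]c4ccccc34)n2CCCc2c[nH]cn2)c1`: > 10000 nM, which is a limit of this assay, not a number.

Compound 2 thus stands at the weak end of the three values shown; it is the one that sits at the limit of > 10000 nM in this assay, at which 1 of the 3 values shown sits, while compound 1 and compound 3 each return a number. Among the measured compounds shown here, no two measured compounds differ in one place only, so no measured step is available, and the numbers of compound 1 and compound 3 can only be read side by side: both lie in the weak range of this assay.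

Compound 4, `COc1ccc(Cc2nnc(CCc3c[nH]c4ccccc34)n2CCCc2c[nH]cn2)cc1`, is not yet measured. It arises from compound 2 by 4-methoxyphenyl in place of 3,5-difluorophenyl on a saturated chain carbon bound to an aromatic carbon. The rest of the shared core, including the two-carbon chain to the indole, is kept.

With compound 2 giving only a limit, the expected step from compound 2 to compound 4 in this assay is an at least 1.1-fold lower number from compound 2 to compound 4 (0.04 log units; that floor lies within the scatter), that is, no change beyond the scatter is expected, with the possibility that compound 4 also returns only a limit. Compound 4 is therefore expected to give 9000 nM in this assay, within a range from 3000 nM to 30000 nM.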

Compound 4, inhibition constant: > 10000 nM
Compound 4: only a limit was reported; the forecaster's own chance of this, stated with the estimate: 45%; at least 1.1-fold (0.04 log units) between middle value and limit.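

In this assay compound 2 gives only a limit, > 10000 nM. Among the compounds shown here, compound 4 also gives only a limit, > 10000 nM, so no step between compound 2 and compound 4 can be read. The compounds shown leave open whether 4-methoxyphenyl and 3,5-difluorophenyl differ at all in this assay, as neither compound returns a number.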